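Notes on a methylphenyl amine ketone series

The source may hold more compounds than are shown below. What is called first, only, known or untested is meant among the compounds shown, and "the series" means these compounds.

Three compounds of the series carry a measurement and a fourth does not. Compound 1 `Cc1ccc(/C=C2\CCCC(CN(C)c3ccc(C)cc3)C2=O)cc1` is the parent; compound 2 `Cc1ccc(/C=C2\CCCC(CN(C)c3cccc(C)c3)C2=O)cc1` differs from it by 3-methylphenyl in place of 4-methylphenyl on an amine nitrogen, and compound 3 `Cc1ccc(N(C)CC2CCC/C(=C\c3ccc(S(C)(=O)=O)cc3)C2=O)cc1` differs from it by methylsulfonyl in place of methyl on an aromatic carbon. Compound 4 `Cc1cccc(N(C)CC2CCC/C(=C\c3ccc(S(C)(=O)=O)cc3)C2=O)c1` is the one still to be run.

In a functional assay on the whole organism (strain Wistar) for inhibition, with Rattus norvegicus as the target, read by paw edema, with stated times of 1 h and 3 h, at a dose of 200 mg/kg by the oral route (a higher number here means more inhibition at the dose given (going by the name of the read-out), a lower number less inhibition), compound 1 gives 38.3%. Compound 2 gives 36.2% in this assay, and compound 3 gives 31.9% there. The first change, a number 2.1 percentage points lower from compound 1 to compound 2 (within the scatter), is within the scatter. The second, a number 6.4 percentage points lower from compound 1 to compound 3 (within the scatter), is also within the scatter, so none of the three compounds can be ranked against the others on these numbers.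

Compound 4 stands to compound 3 as compound 2 stands to compound 1: the difference is 3-methylphenyl in place of 4-methylphenyl on an amine nitrogen, and the place of the change is described in the same words in both pairs, so it is the same change made on the other core. The two cores differ by methylsulfonyl in place of methyl on an aromatic carbon. Going by the values given here, the only measured instance of the change is the step from compound 1 to compound 2, which stayed within the scatter.

On that basis the expected step for compound 4 is a number 1.9 percentage points lower from compound 3 to compound 4 (within the scatter), set beside the measured a number 2.1 percentage points lower from compound 1 to compound 2 (within the scatter). Compound 4 is therefore estimated at 30% in this assay, with an expected range from 20% to 40%.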

Compound 4, a percentage reported as inhibition, in the whole organism at one dose (the size of the read-out at that dose, not a potency): 36.2%
For compound 4 the middle estimate is 6.2 percentage points below the measured one; the range from low to high includes it.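

In this assay, 3-methylphenyl in place of 4-methylphenyl on an amine nitrogen, now read on the core of compound 3, gives a number 4.3 percentage points higher from compound 3 to compound 4 (within the scatter), and this reading does not differ beyond the scatter from the earlier one on the core of compound 1: the same change on two cores in this assay, a number 2.1 percentage points lower (within the scatter) from compound 1 to compound 2 and a number 4.3 percentage points higher (within the scatter) from compound 3 to compound 4, 6.4 percentage points apart, within the scatter of two such steps.

Methylsulfonyl in place of methyl on an aromatic carbon, read with the 3-methylphenyl group in place, gives no change at the digits printed from compound 2 to compound 4 (within the scatter), and this too agrees within the scatter with its earlier reading: the same change on two cores in this assay, a number 6.4 percentage points lower (within the scatter) from compound 1 to compound 3 and no change at the digits printed (within the scatter) from compound 2 to compound 4, 6.4 percentage points apart, within the scatter of two such steps.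

Both changes are therefore compatible with carrying over from one core to the other, but since all four steps lie within the scatter, this does not show that either change has an effect on any core, or that an effect is the same on both.

The compounds shown leave open whether a different group on the amine nitrogen, such as an unsubstituted phenyl or a 4-chlorophenyl, would give a step beyond the scatter. They also leave open whether a carboxylic acid or a nitrile in place of the methylsulfonyl group would do so, and each reading here comes from a single oral dose, so none of them gives a potency.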